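Fluoro step on the benzyloxy group of compound 2

The compounds below may be only part of what the source reports. "The series", "measured", "known", "first", "only" and "open" are said of these compounds alone.

Compound 1 `COc1cc(OC)c2c(c1)C(C(O)c1ccc(OCc3ccccc3)cc1)OC2=O`: > 40000 nM (a limit)
Compound 2 `COc1cc(OC)c2c(c1)/C(=C/c1ccc(OCc3ccccc3)cc1)OC2=O`: > 40000 nM (a limit)

In an ADME assay on RAW264.7 cells (Mus musculus) for cytotoxicity, read by MTT assay, with a stated time of 24 h, in the absence of a further agent (on this read-out higher numbers stand for weaker inhibition and lower numbers for stronger inhibition), compound 2 gives > 40000 nM as a limit and not a number. Compound 3 `COc1cc(OC)c2c(c1)/C(=C/c1ccc(OCc3ccc(F)cc3)cc1)OC2=O` differs from it by fluoro in place of hydrogen on an aromatic carbon in one place: fluoro in place of hydrogen on an aromatic carbon, turning benzyloxy into (4-fluorobenzyl)oxy. No measured step sizes this change, so none beyond the scatter is expected in this assay with compound 2 resting on the limit of > 40000 nM in this assay, at which 2 of the 2 values shown sit, alone. The estimated step that the limit leaves unreadable from compound 2 to compound 3 is expected to stay within the scatter. Compound 3 is estimated at 45000 nM with a range from 15000 nM to 100000 nM and may also come out only as a limit.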

Compound 3, half-maximal inhibitory concentration: > 40000 nM
Compound 3 ended at the assay's limit; the forecaster's own chance of this, stated with the estimate: 70%; the middle value is on the limit's open side.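

No step can be read from compound 2 to compound 3 in this assay, because both compounds rest on the same limit: the limit of > 40000 nM in this assay, at which 3 of the 3 values shown sit.

The compounds shown leave open what size, if any, the fluoro step has in this assay.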